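The source may report more compounds than this note shows. Statements on the series, on what has been measured and on what is new or still open speak of the compounds shown alone.

Measured so far in a functional assay on ACHN cells (Homo sapiens) for cytotoxicity, read by MTT assay, with a stated time of 48 h; a higher number here means a weaker inhibitor, a lower number a stronger inhibitor:
compound 1 `COc1cc(-c2cc(C(=O)Nc3nc4ccc(F)cc4s3)nc3cc(-c4ccccc4)nn23)cc(OC)c1OC`: 32400 nM
compound 2 `COc1ccc(-c2cc(C(=O)Nc3nc4ccccc4s3)nc3cc(-c4ccccc4)nn23)cc1`: 1690 nM
compound 3 `COc1ccc(-c2cc(C(=O)Nc3nc4ccccc4s3)nc3cc(-c4ccccc4)nn23)cc1OC`: 7940 nM

Compound 2 holds the lowest number of the three; the nearest is compound 3, reached by a 4.7-fold higher number from compound 2 to compound 3 (0.67 log units; beyond the scatter), and compound 1 lies furthest off. Compound 4 `COc1ccc(-c2cc(C(=O)Nc3nc4cc(C)c(C)cc4s3)nc3cc(-c4ccccc4)nn23)cc1` is not yet measured; it changes compound 2 by 5,6-dimethyl-1,3-benzothiazol-2-yl in place of 1,3-benzothiazol-2-yl on an amide-type nitrogen. Among the compounds with values here, no measured step touches this ring on its own: compound 1 differs from compound 2 in two places at once, and the single step known concerns a methoxy elsewhere. The change is therefore unanchored, and a step of at most modest size in this assay is expected, direction open. Compound 4 is estimated at 2500 nM, range 700 nM to 9000 nM, which means an expected 1.5-fold higher number from compound 2 to compound 4 (0.17 log units; within the scatter).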

Compound 4, half-maximal inhibitory concentration: 22400 nM
The estimate for compound 4 lay 9.0-fold (0.95 log units) below the measured number; the measured number lies above the stated range.
By their numbers in this assay, from the lowest: compound 2; then compound 3; then compounds 4 and 1 (each within the scatter of the next).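

In this assay, within the data shown here, the group on the amide-type nitrogen is changed on its own for the first time, and 5,6-dimethyl-1,3-benzothiazol-2-yl in place of 1,3-benzothiazol-2-yl gives a 13-fold higher number from compound 2 to compound 4 (1.12 log units; beyond the scatter) in a large step. This position is therefore sensitive to substitution, at least for this pair of methyl groups. Nothing available gives a reason for the step.

From the compounds shown here alone, whether a single methyl on this ring would give a comparable step stays open. Also open, going by these compounds, is how an amine or a carboxylic acid on the same ring would read in this assay in place of the methyl groups.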